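Replacing Iodo with Methylsulfanyl in Compound 3

The compounds below may be only part of what the source reports. "The series", "measured", "known", "first", "only" and "open" are said of these compounds alone.

Measured so far in a functional assay on HL-60 cells (Homo sapiens) for antiproliferative activity, with a stated time of 24 h; a lower number here means a stronger inhibitor, a higher number a weaker inhibitor:
Compound 1, `NC(=O)c1c(NC(=O)c2ccccc2Cl)sc2c1CCN(Cc1ccccc1)C2`, gives 12000 nM.
Compound 2, `NC(=O)c1c(NC(=O)c2ccccc2Cl)sc2c1CCN(Cc1ccc(Cl)cc1Cl)C2`, gives 8010 nM.
Compound 3, `NC(=O)c1c(NC(=O)c2ccccc2Cl)sc2c1CCN(C(=S)Nc1ccccc1I)C2`, gives 4430 nM.

Among the measured compounds shown here, compound 3 has the lowest number of the three, but only one of its steps is beyond the scatter: a 2.7-fold lower number from compound 1 to compound 3 (0.43 log units; beyond the scatter). The step of a 1.8-fold lower number from compound 2 to compound 3 (0.26 log units; within the scatter) stays within the scatter, as does a 1.5-fold lower number from compound 1 to compound 2 (0.18 log units; within the scatter). Compound 4, `CSc1ccccc1NC(=S)N1CCc2c(sc(NC(=O)c3ccccc3Cl)c2C(N)=O)C1`, keeps everything in compound 3 and makes one change: methylsulfanyl in place of iodo on an aromatic carbon. For the measured compounds named here, none of the measured steps bears on this position; all three alter the group on the ring amine nitrogen, and none changes a substituent on the 2-iodophenyl group. There is therefore no measured guide to the size or direction of this step, and the plain expectation is a number close to that of compound 3, with no step beyond the scatter in either direction. Compound 4 is estimated at 5000 nM, with a range from 2000 nM to 14000 nM. This estimate means an expected step of a 1.1-fold higher number from compound 3 to compound 4 (0.05 log units; within the scatter).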

Compound 4, half-maximal inhibitory concentration: 14600 nM
For compound 4 the middle estimate is 2.9-fold (0.47 log units) below the measured one; measured number above the stated range.
By their numbers in this assay, from the lowest: compounds 3, 2, 1 and 4 (each within the scatter of the next, the first and the last beyond it).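

In this assay, among the compounds shown here, the group on this aromatic carbon proves able to shift the number: methylsulfanyl in place of iodo gives a 3.3-fold higher number from compound 3 to compound 4 (0.52 log units; beyond the scatter), the first measured change at this position and one beyond the scatter. With methylsulfanyl there, the new group on the ring amine nitrogen no longer stands apart from the benzyl-type groups, with a 1.2-fold higher number from compound 1 to compound 4 (0.09 log units; within the scatter) and a 1.8-fold higher number from compound 2 to compound 4 (0.26 log units; within the scatter), both within the scatter, so the modest edge of compound 3 over compound 1 is tied to the iodo in this small set. No measurement shown here offers an explanation for this step.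

From the compounds shown here alone, what chloro, methoxy or an amine would give on this same aromatic carbon stays open. With only iodo and methylsulfanyl compared at this position, no trend across groups can yet be drawn.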